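Trimming the hydrazone arm of a pyrazolopyrimidine ester series

The compounds below may be only part of what the source reports. "The series", "measured", "known", "first", "only" and "open" are said of these compounds alone.

Two compounds carry the same core and differ only on the amine nitrogen. Compound 1 `CCOC(=O)C1=C(N/N=C(/C#N)C(=O)OCC)Nc2[nH]nc(C)c2C1c1ccc(N(C)C)cc1` gives 35600 nM in a functional assay on MCF7 cells (Homo sapiens) for inhibition, read by MTT assay, with a stated time of 48 h; a higher number here means a weaker inhibitor, a lower number a stronger inhibitor. Compound 2 `CCOC(=O)C1=C(N/N=C(/Cl)c2ccc([N+](=O)[O-])cc2)Nc2[nH]nc(C)c2C1c1ccc(N(C)C)cc1` gives 52700 nM in the same assay, the higher of the two numbers, and the change a 1.5-fold higher number from compound 1 to compound 2 (0.17 log units; within the scatter) is within the scatter. Compound 3 `CCOC(=O)C1=C(N/N=C(/Cl)C#N)Nc2[nH]nc(C)c2C1c1ccc(N(C)C)cc1` has not yet been measured; it differs from compound 2 by cyano in place of 4-nitrophenyl on a carbon with a double bond to nitrogen. Among the measured compounds shown here, the only measured step that bears on this position is the one from compound 1 to compound 2, which also reworked the group on the hydrazone carbon and stayed within the scatter, so no step beyond the scatter is expected in this assay in either direction. Compound 3 is therefore expected to show roughly a 1.3-fold lower number from compound 2 to compound 3 (0.10 log units; within the scatter), with an estimated value of 42000 nM and a range from 15000 nM to 120000 nM.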

Compound 3, half-maximal inhibitory concentration: 23200 nM
Beside the measured number, compound 3's estimate is 1.8-fold (0.26 log units) above it, and the stated range covers the measured number.
By their numbers in this assay, from the lowest: compounds 3, 1 and 2 (each within the scatter of the next, the first and the last beyond it).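

In this assay, the carbon with a double bond to nitrogen now shows a modest change that lies beyond the scatter: cyano in place of 4-nitrophenyl gives a 2.3-fold lower number from compound 2 to compound 3 (0.36 log units; beyond the scatter) and so separates two compounds that differ only in that group. By contrast, a 1.5-fold lower number from compound 1 to compound 3 (0.19 log units; within the scatter) stays within the scatter, so the larger exchange on the amine nitrogen leaves the number where it was. No measurement shown here explains the step from 4-nitrophenyl to cyano.

The compounds shown leave open whether an amine, a carboxylic acid or a longer chain on this carbon would move the number further in either direction. They also leave open what a plain phenyl ring would give, and whether a group other than chlorine on the same carbon would change the picture.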